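Adding a methyl to the methoxy-bearing ring of compound 3

The source may hold more compounds than are shown below. What is called first, only, known or untested is meant among the compounds shown, and "the series" means these compounds.

Measured so far:
compound 1 `CCOc1cccc(C(=O)NCc2c(C)cc(C)[nH]c2=O)c1C`: 2.1
compound 2 `Cc1cc(C)c(CN2CCc3c(Cl)cc(-c4c(C)n[nH]c4C)c(Cl)c3C2=O)c(=O)[nH]1`: 3.4
compound 3 `COc1cccc(C(=O)NCc2c(C)cc(C)[nH]c2=O)c1`: 1.7

The three compounds were examined in a physicochemical assay for lipophilicity, at pH 7.4; on this read-out higher numbers stand for higher lipophilicity and lower numbers for lower lipophilicity. Compound 3 stands lowest of the three numbers. Its nearest neighbour is compound 1, whose value is higher by an amount beyond the scatter, and the furthest is compound 2, whose value lies well beyond the scatter above it.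

The step now followed leads from compound 3 to compound 4 `COc1cccc(C(=O)NCc2c(C)cc(C)[nH]c2=O)c1C`, which has not yet been measured in this assay. The change is a small one: methyl in place of hydrogen on an aromatic carbon. Nothing else in the molecule is altered.

Among the compounds with values here, no step between two measured compounds isolates this single change, so the expectation has to rest on the values themselves. Compound 1 carries a methyl at the same place and gives 2.1, while compound 3 gives 1.7; compound 1 also differs in its alkoxy group, so this comparison is only a guide. A small upward step in this assay is expected, beyond the scatter, of about a number 0.40 log units higher from compound 3 to compound 4 (beyond the scatter). For compound 4 the estimated value is 2.1, with a range from 1.7 to 2.5.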

Compound 4, distribution coefficient: 1.5
Compound 4: the middle estimate sits 0.60 log units above what was measured; the whole stated range lies above it.
By their numbers in this assay, from the lowest: compounds 4 and 3 (each within the scatter of the next); then compound 1; then compound 2.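

In this assay, methyl in place of hydrogen on an aromatic carbon, ortho to a large group and ortho to a methoxy group, gives a number 0.20 log units lower from compound 3 to compound 4 (within the scatter), so this added carbon leaves no change that can be told from the ordinary spread of repeated measurements. Within the data shown here, with that ring methyl present in both compounds, the one-place change in the alkoxy group, hydrogen in place of methyl on a saturated chain carbon bound to an oxygen on an aromatic ring, gives a number 0.60 log units lower from compound 1 to compound 4 (beyond the scatter), a step that lies beyond the scatter and that the earlier compounds could not isolate. Nothing measured here explains why one added carbon registers on this read-out and the other does not.

As far as these compounds go, what stays open is whether the alkoxy step would hold on a ring without the methyl, since this single pair cannot establish a general pattern. From the compounds shown here alone, it is equally open whether a larger group at the ring position, such as an ethyl or a fluorine atom, or a longer chain such as propoxy in place of the methoxy group, would continue either trend.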